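Amide series: aryl against alkyl on the carbonyl carbon

The compounds below may be only part of what the source reports. "The series", "measured", "known", "first", "only" and "open" are said of these compounds alone.

Measured in an assay on LtK cells with ATP-sensitive inward rectifier potassium channel 11 (Homo sapiens) as the target; on this read-out higher numbers stand for an effect only at larger amounts of compound and lower numbers for an effect already at smaller amounts:
compound 1 `CCC(CC)C(=O)Nc1c(C(O)(C(F)(F)F)C(F)(F)F)ccc2ccccc12` gives 4340 nM
compound 2 `CCCC(C)C(=O)Nc1c(C(O)(C(F)(F)F)C(F)(F)F)ccc2ccccc12` gives > 10000 nM, a limit of the assay
compound 3 `N#Cc1cccc(C(=O)Nc2c(C(O)(C(F)(F)F)C(F)(F)F)ccc3ccccc23)c1` gives 12 nM

Compound 3 stands lowest of the numbers shown in this assay; its nearest neighbour is compound 1, separated by a 360-fold lower number from compound 1 to compound 3 (2.56 log units; beyond the scatter). The value of compound 2 is a limit (the limit of > 10000 nM in this assay, at which 1 of the 3 values shown sits). Compound 4 `O=C(Nc1c(C(O)(C(F)(F)F)C(F)(F)F)ccc2ccccc12)c1ccc(Cl)cc1` differs from compound 3 by 4-chlorophenyl in place of 3-cyanophenyl on a carbonyl carbon. Within the data shown here, no measured step exchanges one aryl group for another. Among the measured compounds shown here, the steps that bear on it are a 360-fold lower number from compound 1 to compound 3 (2.56 log units; beyond the scatter) and an at least 830-fold lower number from compound 2 to compound 3 (2.92 log units; beyond the scatter), both replacing an alkyl group by 3-cyanophenyl, whereas an at least 2.3-fold higher number from compound 1 to compound 2 (0.36 log units; beyond the scatter) moves between two alkyl groups. Compound 4 keeps an aryl group on the carbonyl carbon. For compound 4 the expected step is a 2.5-fold higher number from compound 3 to compound 4 (0.40 log units; beyond the scatter), small and uncertain in direction. The estimated value for compound 4 is 30 nM, between 5 nM and 200 nM.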

Compound 4, half-maximal effective concentration: 570 nM
Compound 4: the middle estimate sits 19-fold (1.28 log units) below what was measured, and the stated range ends below it.
By their numbers in this assay, from the lowest: compound 3; then compound 4; then compound 1. At a limit, above all of these: compound 2.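

The aryl group is not interchangeable at this position: 4-chlorophenyl in place of 3-cyanophenyl gives a 48-fold higher number from compound 3 to compound 4 (1.68 log units; beyond the scatter). 4-Chlorophenyl still retains much of the aryl-over-alkyl gain, with a 7.6-fold lower number from compound 1 to compound 4 (0.88 log units; beyond the scatter) and an at least 17-fold lower number from compound 2 to compound 4 (1.24 log units; beyond the scatter), though both steps are smaller than those to compound 3. The step from compound 2 starts from a limit, not a number: the limit of > 10000 nM in this assay, at which 1 of the 4 values shown sits.

Compound 3 and compound 4 differ in both the substituent and its place on the ring, and the compounds shown do not separate these two changes. From the compounds shown here alone, whether the nitrile or its placement carries the difference remains open, and 3-chlorophenyl and 4-cyanophenyl groups would address it.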